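Chain extension on the saturated chain carbon: compound 4

The compounds below may be only part of what the source reports. "The series", "measured", "known", "first", "only" and "open" are said of these compounds alone.

Among the compounds with values here, in a functional assay on HL-60 cells (Homo sapiens) for cytotoxicity, read by WST assay, with a stated time of 48 h (on this read-out lower numbers stand for stronger inhibition and higher numbers for weaker inhibition), compound 3 `C=CC[C@H]1C[C@@H]([C@@H](O)c2ccccc2)CO[C@@H]1c1ccccc1` gives 36000 nM, the highest number of the three measured members. Compound 1 `CCCCCC/C=C/C[C@H]1C[C@@H]([C@@H](O)c2ccccc2)CO[C@@H]1c1ccccc1` gives 4990 nM and compound 2 `COc1cccc(/C=C/C[C@H]2C[C@@H]([C@@H](O)c3ccccc3)CO[C@@H]2c2ccccc2)c1` gives 9620 nM. Compound 4 `Oc1cccc(/C=C/C[C@H]2C[C@@H]([C@@H](O)c3ccccc3)CO[C@@H]2c2ccccc2)c1` is not yet measured; it differs from compound 3 by 2-(3-hydroxyphenyl)ethenyl in place of vinyl on a saturated chain carbon bound to a saturated ring carbon. Within the data shown here, two measured steps bear on this change. a 7.2-fold higher number from compound 1 to compound 3 (0.86 log units; beyond the scatter) and a 3.7-fold higher number from compound 2 to compound 3 (0.57 log units; beyond the scatter) both show that cutting the chain on this carbon back to vinyl raises the number. Among the measured compounds shown here, the reverse of the second of these, 2-(3-methoxyphenyl)ethenyl in place of vinyl, is the closest match to the change in hand, the entering ring carrying a hydroxyl where compound 2 carries a methoxy group; no measured pair tells how that exchange alone plays out. For compound 4 the expected step is a 3.6-fold lower number from compound 3 to compound 4 (0.56 log units; beyond the scatter), a lower number in this assay of about the size of that reversed step, beyond the scatter. Compound 4 is estimated at 10000 nM, with a range from 4000 nM to 25000 nM.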

Compound 4, half-maximal inhibitory concentration: 12800 nM
Compound 4: the middle estimate sits 1.3-fold (0.11 log units) below what was measured; the measured number falls inside the stated range.
By their numbers in this assay, from the lowest: compounds 1, 2 and 4 (each within the scatter of the next, the first and the last beyond it); then compound 3.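

In this assay the exchange of vinyl for 2-(3-hydroxyphenyl)ethenyl gives a 2.8-fold lower number from compound 3 to compound 4 (0.45 log units; beyond the scatter) and shows that the lower number on extending this chain does not depend on the methoxy group of compound 2. Hydrogen in place of methyl on the aromatic oxygen gives a 1.3-fold higher number from compound 2 to compound 4 (0.12 log units; within the scatter) and so leaves the two ring-bearing chains unseparated in this read-out. Set against the hexyl-bearing chain, 3-hydroxyphenyl gives a 2.6-fold higher number from compound 1 to compound 4 (0.41 log units; beyond the scatter) and this step lies beyond the scatter, whereas the step from compound 1 to the methoxy compound 2 lies within it.

From the compounds shown here alone, how an amine or a carboxylic acid on the entering aromatic ring, or a chain longer than hexyl, would read at this carbon remains open. Nothing available gives a reason for any of these steps.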